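The source may report more compounds than this note shows. Statements on the series, on what has been measured and on what is new or still open speak of the compounds shown alone.

- compound 1 `CCC(=O)Nc1c(C)c(C)c2c(c1C)CC(C)(C)O2`: > 100 mg/kg
- compound 2 `Cc1c(C)c2c(c(C)c1NS(C)(=O)=O)CC(C)(C)O2`: > 100 mg/kg

In a functional assay on the whole organism with Mus musculus as the target (a higher number here means that more compound is needed for the effect, a lower number that less compound is needed), compound 2 gives > 100 mg/kg, which is a limit and not a number. Going by the values given here, the same holds across the series so far, with the limit of > 100 mg/kg in this assay, at which 2 of the 2 values shown sit. Compound 3 `Cc1c(C)c2c(c(C)c1Nc1ccccc1)CC(C)(C)O2` carries phenyl in place of methylsulfonyl on a nitrogen on an aromatic ring. Among the compounds with values here, the only measured change at this nitrogen is a step that the two limits leave unreadable from compound 1 to compound 2, so it offers no size to carry over. The expected step, only weakly grounded, is an at least 1.4-fold lower number from compound 2 to compound 3 (0.15 log units; that floor lies within the scatter), towards less compound needed, though another limit is quite possible. For compound 3 the estimate is 70 mg/kg, with an expected range of 15 mg/kg to 200 mg/kg.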

Compound 3, dose for 50% inhibition: > 50 mg/kg
Compound 3: only a limit was reported; the forecaster's own chance of this, stated with the estimate: 50%; the middle value lies beyond the limit too.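

Going by these compounds alone, compound 1, compound 2 and compound 3 all give only limits in this assay, not numbers, so no step between them can be read. As far as these compounds go, whether propanoyl, methylsulfonyl and phenyl on this nitrogen differ at all in the dose needed stays open.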